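The source may hold more compounds than are shown below. What is called first, only, known or untested is meant among the compounds shown, and "the series" means these compounds.

Compound 1 `COc1cccc(CN2CC=C(CCC(=O)NO)C2=O)c1` is a hydroxamic acid carrying a methoxy-substituted benzyl group on the nitrogen of its core. In a functional assay on NCI-H23 cells (Homo sapiens) for antiproliferative activity (on this read-out lower numbers stand for stronger inhibition of growth and higher numbers for weaker inhibition of growth), compound 1 gives 1970 nM, the lowest of the two numbers recorded. Going by the values given here, the other measured compound, compound 2 `COc1ccccc1CCCN1CC=C(CCC(=O)NO)C1=O`, which carries a longer linker and a differently placed methoxy group, gives in this assay a value of 4490 nM, a gap beyond the usual scatter; no single-point step links these two structures.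

Compound 3 `O=C(CCC1=CCN(Cc2cccc(C(F)(F)F)c2)C1=O)NO` awaits measurement. It differs from compound 1 by trifluoromethyl in place of methoxy on an aromatic carbon. Among the compounds with values here, with no comparable step available among the measured compounds, the effect of this change is an open question, and compound 3 is expected to stay close to compound 1 in this assay, with a step of a 1.1-fold lower number from compound 1 to compound 3 (0.04 log units; within the scatter) that is expected to lie within the scatter. Compound 3 is thus estimated at 1800 nM, within a range from 700 nM to 5000 nM.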

Compound 3, concentration for 50% growth inhibition: 680 nM
Compound 3: middle estimate off by 2.6-fold (0.42 log units), on the high side; measured number below the stated range.
By their numbers in this assay, from the lowest: compound 3; then compound 1; then compound 2.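

In this assay, going by these compounds alone, trifluoromethyl in place of methoxy on an aromatic carbon, meta to a large group, gives a 2.9-fold lower number from compound 1 to compound 3 (0.46 log units; beyond the scatter) and supplies the first step that changes one place only. It shows that this position on the six-membered aromatic ring responds to the group it carries: with the rest of the structure unchanged, this exchange alone moves the number beyond the scatter. Nothing available accounts for the size or direction of this step.

The compounds shown leave open how a nitrile, a chlorine or an amine at the same place would compare with trifluoromethyl. They also leave open whether the same exchange would give a similar step on the longer linker of compound 2.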